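Difluorophenyl hydrazone on the dimethylaminoethyl triazole core

The source may report more compounds than this note shows. Statements on the series, on what has been measured and on what is new or still open speak of the compounds shown alone.

Measured so far in a functional assay on U-87MG ATCC cells (Homo sapiens) for cytotoxicity, read by MTT assay, with a stated time of 72 h; a higher number here means a weaker inhibitor, a lower number a stronger inhibitor:
compound 1, `CN(C)CCn1cnnc1-c1cc(Oc2ccc(NC(=O)N/N=C/c3cc(C(C)(C)C)cc(C(C)(C)C)c3O)cc2F)ccn1`: 520 nM
compound 2, `COc1ccc(OC)c(/C=N/NC(=O)Nc2ccc(Oc3ccnc(-c4nncn4CCN(C)C)c3)c(F)c2)c1`: 6400 nM
compound 3, `Cn1ncnc1-c1cc(Oc2ccc(NC(=O)N/N=C/c3ccccc3)cc2F)ccn1`: > 100000 nM

Three compounds share a diaryl ether urea hydrazone core and differ at the aryl group on the hydrazone carbon and at the substituent on the triazole. In this assay compound 2 stands as the highest of the two numbers that were read as numbers. Its nearest neighbour is compound 1, whose lower number lies beyond the scatter of repeated measurements. For compound 3 the result is a limit, not a number, as the limit of > 100000 nM in this assay, at which 1 of the 3 values shown sits, states.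

Compound 4, `CN(C)CCn1cnnc1-c1cc(Oc2ccc(NC(=O)N/N=C/c3ccc(F)cc3F)cc2F)ccn1`, is not yet measured. It differs from compound 2 by 2,4-difluorophenyl in place of 2,5-dimethoxyphenyl on a carbon with a double bond to nitrogen. Among the compounds with values here, no step between two measured compounds isolates this change, so the expectation rests on the spread of the three measured values alone. Compound 2 already gives 6400 nM in this assay. Compound 3, which also carries an aryl group without acceptors on that carbon, reached only a limit. Compound 4 is therefore expected to give a number somewhat higher than compound 2, with a step of a 2.3-fold higher number from compound 2 to compound 4 (0.37 log units; beyond the scatter) in this assay. The estimate for compound 4 is 15000 nM, within a range from 4000 nM to 80000 nM, with a real chance that only a limit is reported.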

Compound 4, half-maximal inhibitory concentration: 1900 nM
The estimate for compound 4 lay 7.9-fold (0.90 log units) above the measured number; measured number below the stated range.
By their numbers in this assay, from the lowest: compound 1; then compound 4; then compound 2. At a limit, above all of these: compound 3.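

With this pair, this assay gains its first reading of a single change on the shared core: 2,4-difluorophenyl in place of 2,5-dimethoxyphenyl on a carbon with a double bond to nitrogen gives a 3.4-fold lower number from compound 2 to compound 4 (0.53 log units; beyond the scatter), so in this pair the aryl group with 0 hydrogen-bond acceptors gives the lower number, not the one with 2. Compound 3 is reported only as a limit, and it differs from compound 4 in more than one place, so it cannot be read against this step. Nothing measured here gives a reason for the step, and the change swaps two methoxy groups for two fluorine atoms in a single move, so neither substituent can be assessed alone.

The compounds shown leave open whether a plain phenyl, a 4-fluorophenyl or a 2,4-dichlorophenyl at this position would keep the lower number on the same core. As far as these compounds go, it also remains open whether a single hydroxyl on the aryl ring, without the tert-butyl groups, would come near compound 1 at 520 nM.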